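A few compounds are considered here, and "the series" means these few. Any claim that something is new, unique, unknown or untested is made for them only; others in the source may bear on it.

Measured so far in an assay on TT cells for inhibition of proto-oncogene tyrosine-protein kinase receptor Ret variant C634W (Homo sapiens), read by MTT assay, with a stated time of 10 days; a higher number here means a weaker inhibitor of growth, a lower number a stronger inhibitor of growth:
compound 1, `CC(C)n1nc(-c2ccon2)c2c(N)ncnc21`: 7920 nM
compound 2, `CC(C)n1nc(-c2cc(C(C)(C)C)on2)c2c(N)ncnc21`: a limit, see below
compound 3, `Nc1ncnc2c1c(-c1cc(C3CC3)on1)nn2C1CCCCC1`: 290 nM

Compound 2 gives > 10000 nM in this assay, which is the limit of > 10000 nM in this assay, at which 1 of the 3 values shown sits, and not a number. Among the two numbers, compound 3 gives the lower one, and its gap to compound 1 lies beyond the usual scatter.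

Compound 4, `CCCCCCCn1nc(-c2cc(C3CC3)on2)c2c(N)ncnc21`, has not yet been measured in this assay. It differs from compound 3 in one place: heptyl in place of cyclohexyl on an aromatic nitrogen. Among the measured compounds shown here, the single measured step, an at least 1.2-fold higher number from compound 1 to compound 2 (0.10 log units; that floor lies within the scatter), concerns a group on an aromatic carbon of the attached ring, not the group on the ring nitrogen, so it does not bear on this change. For the measured compounds named here, no measured pair varies the group on the ring nitrogen alone; compound 1 and compound 3 differ there but also elsewhere. With nothing to rest on, a modest weakening is expected, with wide uncertainty. Compound 4 is therefore estimated at 800 nM, within 200 nM to 3500 nM, an expected step of a 2.8-fold higher number from compound 3 to compound 4 (0.44 log units; beyond the scatter).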

Compound 4, concentration for 50% growth inhibition: > 10000 nM
Compound 4 ended at the assay's limit; the forecaster's own chance of this, stated with the estimate: 10%; middle value at least 12-fold (1.09 log units) away from the limit.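

This is the only pair shown that changes the group on the aromatic nitrogen alone, and in this assay it gives an at least 34-fold higher number from compound 3 to compound 4 (1.53 log units; beyond the scatter). Growth inhibition at this position therefore depends strongly on which group is present, even though cyclohexyl and heptyl are both made only of carbon and neither has hydrogen-bond donors or acceptors. The result for compound 4 is a limit and not a number: the limit of > 10000 nM in this assay, at which 2 of the 4 values shown sit.

With just these two groups compared on this core, the data cannot separate the effect of losing the ring from the effect of the chain's length or shape. A shorter chain such as butyl, or a smaller ring such as cyclopentyl, in the same place would help tell these apart.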